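The source may report more compounds than this note shows. Statements on the series, on what has been measured and on what is new or still open speak of the compounds shown alone.

Working notes on the series. In a functional assay on KARPAS-422 cells (Homo sapiens) for antiproliferative activity, read by resazurin assay, with a stated time of 72 h (on this read-out lower numbers stand for stronger inhibition and higher numbers for weaker inhibition), compound 1 `Cc1cc(C)c(CN2CCc3c(Cl)cc([C@@H](CO)[C@@H]4CCCO4)c(Cl)c3C2=O)c(=O)[nH]1` gives 1220 nM. Compound 2 `COc1cc(C)[nH]c(=O)c1CN1CCc2c(Cl)cc([C@@H](O)C3COC3)c(Cl)c2C1=O` gives 10600 nM in this assay, a gap beyond the scatter, so compound 1 stands lowest of the two numbers. Compound 3 `Cc1cc(C)c(CN2CCc3c(Cl)cc([C@H](CO)[C@H]4CCOC4)c(Cl)c3C2=O)c(=O)[nH]1` is not yet measured and differs from compound 1 by a group of 8 heavy atoms (6 carbon, 2 oxygen; one five-membered non-aromatic ring with 1 hetero atom) in place of a group of 8 heavy atoms (6 carbon, 2 oxygen; one five-membered non-aromatic ring with 1 hetero atom), on an aromatic carbon. Going by the values given here, no measured pair shows a change of this kind, so nothing anchors its size. A small step in either direction, not beyond the scatter, is expected: a 1.2-fold higher number from compound 1 to compound 3 (0.09 log units; within the scatter). Compound 3 is estimated at 1500 nM in this assay, within 500 nM to 4500 nM.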

Compound 3, half-maximal inhibitory concentration: 15 nM
Beside the measured number, compound 3's estimate is 100-fold (2.00 log units) above it; measured number below the stated range.
By their numbers in this assay, from the lowest: compound 3; then compound 1; then compound 2.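

In this assay, the group on the aromatic carbon ortho to a chloro group is exchanged for one with the same atoms, the same counts of hydrogen-bond donors and acceptors and the same number of defined stereocentres, and this gives an 81-fold lower number from compound 1 to compound 3 (1.91 log units; beyond the scatter). This position therefore responds strongly to how these atoms are joined and arranged, not only to which atoms are present. Nothing available explains the size of this step.

The compounds shown do not separate the effect of ring attachment from that of stereochemistry. Going by these compounds, whether an amine or a carboxylic acid in place of the hydroxyl on the compound 3 group would be tolerated remains open.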